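The source may hold more compounds than are shown below. What is called first, only, known or untested is meant among the compounds shown, and "the series" means these compounds.

Among the measured compounds shown here, in a functional assay on SK-OV-3 cells (Homo sapiens) for cytotoxicity (on this read-out higher numbers stand for weaker inhibition of growth and lower numbers for stronger inhibition of growth), compound 1 `COc1ccc(C2=C(c3ccc(SC)cc3)CC3CCCN3C2=O)cc1` gives 3000 nM and compound 2 `CSc1ccc(C2=C(c3ccc(OCC4CO4)cc3)C(=O)N3CCCC3C2)cc1` gives 10000 nM as the higher of the only two numbers. For the measured compounds named here, the one measured step is a 3.3-fold higher number from compound 1 to compound 2 (0.52 log units; beyond the scatter) with oxiran-2-yl in place of hydrogen on a saturated chain carbon bound to an oxygen on an aromatic ring.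

Compound 3 `CSc1ccc(C2=C(c3ccc(Br)cc3)C(=O)N3CCCC3C2)cc1` changes the same substituent of compound 2: bromo in place of (oxiran-2-yl)methoxy on an aromatic carbon para to a large group. The modest step above is the only one that bears on this place. Going by the values given here, no measured compound carries bromo, so the entering group is untested and the expectation stays loose. Losing the oxiran-2-yl is the part of the change with a measured guide, as compound 1 at 3000 nM lacks it. A step of similar modest size towards a lower number is therefore expected in this assay and could be partly lost within the scatter. The estimated step is a 3.3-fold lower number from compound 2 to compound 3 (0.52 log units; beyond the scatter) on this reasoning. Compound 3 is expected at 3000 nM (estimated range 800 nM to 10000 nM).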

Compound 3, concentration for 50% growth inhibition: 9000 nM
Beside the measured number, compound 3's estimate is 3.0-fold (0.48 log units) below it; the measured number falls inside the stated range.
By their numbers in this assay, from the lowest: compound 1; then compounds 3 and 2 (each within the scatter of the next).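

At the aromatic carbon para to a large group, bromo and (oxiran-2-yl)methoxy cannot be told apart in this assay, with a 1.1-fold lower number from compound 2 to compound 3 (0.05 log units; within the scatter). The number seen with compound 2 therefore does not depend on the oxiran-2-yl group alone: bromo, with 1 heavy atom, no ring and no hydrogen-bond acceptors, gives a number within the scatter of it, while a 3.0-fold higher number from compound 1 to compound 3 (0.48 log units; beyond the scatter) sets methoxy apart from bromo at the same carbon. Among these three compounds, methoxy is thus the only group at this place linked to a number beyond the scatter of the others, and no accompanying measurement speaks to what lies behind that difference.

As far as these compounds go, it remains open whether hydroxy, dimethylamino or a carboxylic acid at this carbon would read with methoxy or with the other two groups, and so whether compound 1 marks a wider trend or stands alone. Also open, from the compounds shown here alone, is whether this reading would hold with a group other than methylthio, which is common to all three compounds, for example chloro.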